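The compounds below may be only part of what the source reports. "The series", "measured", "known", "first", "only" and "open" are said of these compounds alone.

Compound 2 `O=C1CSC(c2cccc(O)c2)N1CCN1CCCCC1` stands level with compound 1 `O=C1CSC(c2cccc(Cl)c2)N1CCN1CCCCC1` in an ADME assay on Vero cells (Chlorocebus sabaeus) for cytotoxicity, read by neutral red uptake, tested at 98 ug/mL; on this read-out higher numbers stand for a weaker effect at the one concentration tested and lower numbers for a stronger effect: compound 2 gives 100% and compound 1 gives 100%, together the highest of three numbers, while compound 3 `O=C1CSC(c2ccc(O)cc2)N1CCN1CCCCC1` gives 94%. Every step among these three stayed within the scatter: no change at the digits printed from compound 1 to compound 2 (within the scatter), a number 6 percentage points lower from compound 1 to compound 3 (within the scatter) and a number 6 percentage points lower from compound 2 to compound 3 (within the scatter). Compound 4 `COc1cccc(C2SCC(=O)N2CCN2CCCCC2)c1` differs from compound 2 by methyl in place of hydrogen on an oxygen on an aromatic ring. For the measured compounds named here, no measured step puts a methyl on an oxygen, so nothing bears on this change directly; the three steps only show that exchanging chloro for hydroxy, or moving the hydroxy, left the read-out unchanged within the scatter. For compound 4 a step of a number 3 percentage points lower from compound 2 to compound 4 (within the scatter) is expected, none beyond the scatter. Compound 4 is estimated at 97%, between 85% and 100%.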

Compound 4, a percentage reported as activity, at one concentration (the size of the read-out at that concentration, not a potency): 84%
Compound 4: middle estimate off by 13 percentage points, on the high side, and the stated range ends above it.
By their numbers in this assay, from the lowest: compounds 4, 3, 1 and 2 (each within the scatter of the next, the first and the last beyond it).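

For the compounds shown here, on an oxygen on an aromatic ring, methyl in place of hydrogen is the first change here to pass the scatter in this assay, with a number 16 percentage points lower from compound 2 to compound 4 (beyond the scatter) and so a stronger effect at the one concentration tested. Exchanging the chloro group for methoxy gives a number 16 percentage points lower from compound 1 to compound 4 (beyond the scatter), whereas hydroxy in place of chloro gave no change at the digits printed from compound 1 to compound 2 (within the scatter), so of these three groups only methoxy moves the number beyond the scatter. No measurement at hand explains this step. Going by these compounds, whether a longer chain on that oxygen, such as ethyl, or an amine in place of the methoxy would give a similar step remains open.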